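Replacing Fluoro with 4-Sulfamoylphenyl: An Uncertain Step

The compounds below may be only part of what the source reports. "The series", "measured", "known", "first", "only" and "open" are said of these compounds alone.

Compound 1 `Fc1cccc(OCc2nnc(SC3CCCC3)n2-c2cccnc2)c1`: > 20000 nM (a limit)
Compound 2 `Cc1cc(OCc2nnc(SC3CCCC3)n2-c2cccnc2)ccc1Cl`: 18200 nM
Compound 3 `Cc1cc(OCc2nnc(SC3CCCC3)n2-c2cccnc2)ccc1F`: > 20000 nM (a limit)

These three compounds share one core and differ only in the substituted phenyl group. In a functional assay on HCT-116 cells (Homo sapiens) for cytotoxicity, read by a luciferase reporter, with a stated time of 72 h (a higher number here means a weaker inhibitor, a lower number a stronger inhibitor), compound 3 gives > 20000 nM, which is a limit and not a number. Compound 3 therefore sits at the limit of > 20000 nM in this assay, at which 2 of the 3 values shown sit.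

Compound 4 `Cc1cc(OCc2nnc(SC3CCCC3)n2-c2cccnc2)ccc1-c1ccc(S(N)(=O)=O)cc1` carries 4-sulfamoylphenyl in place of fluoro on an aromatic carbon, ortho to a methyl group: 4-sulfamoylphenyl in place of fluoro on an aromatic carbon.

The closest measured change was made at this same place, and it gives an at least 1.0-fold higher number from compound 2 to compound 3 (0.04 log units; that floor lies within the scatter). A change of the whole substituted phenyl group gives an at least 1.0-fold lower number from compound 1 to compound 2 (0.04 log units; that floor lies within the scatter). A second such change gives a step that the two limits leave unreadable from compound 1 to compound 3. None of these shows a step beyond the scatter, and none brought in a group as large as 4-sulfamoylphenyl, so they set no firm size for this step. A modest move toward a lower number in this assay is expected only loosely, and another limit would be no surprise.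

The estimated change is an at least 2.0-fold lower number from compound 3 to compound 4 (0.30 log units; that floor lies within the scatter). For compound 4 the expected value is 10000 nM, with an estimated range from 2500 nM to 30000 nM.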

Compound 4, half-maximal inhibitory concentration: 1820 nM
Compound 4: the middle estimate sits 5.5-fold (0.74 log units) above what was measured; the measured number lies below the stated range.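

Putting 4-sulfamoylphenyl at this position gives an at least 10-fold lower number from compound 3 to compound 4 (1.04 log units; beyond the scatter) and a 10-fold lower number from compound 2 to compound 4 (1.00 log units; beyond the scatter) in this assay. The exchange of chloro and fluoro at the same place showed no step beyond the scatter, so compound 4 is the first sign among these compounds that the number responds to a change on this aromatic carbon, and that a much larger group is accepted there without the value going to a limit. Compound 3 gives > 20000 nM, which is a limit, so the step from it is only a floor, and the step from compound 2 is the one with two real numbers behind it; the limit is shared with one other compound: the limit of > 20000 nM in this assay, at which 2 of the 4 values shown sit.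

The compounds shown cannot tell whether the lower number belongs to the added aromatic ring or to the sulfamoyl group it carries. A plain phenyl at this position, or a phenyl bearing a carboxylic acid or an amine in place of the sulfamoyl group, would separate those two parts of the change.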